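Compound 2 to compound 3: shortening the side chain

The source may report more compounds than this note shows. Statements on the series, on what has been measured and on what is new or still open speak of the compounds shown alone.

Read in a functional assay on A549 cells (Homo sapiens) for cytotoxicity, read by MTT assay, with a stated time of 72 h (a lower number here means a stronger inhibitor, a higher number a weaker inhibitor), compound 2 (`COc1ncc(-c2ccc3nc(NC(=O)NCCN4CCCCC4)nn3c2)cc1NS(=O)(=O)c1ccc(F)cc1`) gives 610 nM and compound 1 (`COc1ncc(-c2ccc3nc(NC(=O)N(C)C)nn3c2)cc1NS(=O)(=O)c1ccc(F)cc1`) gives 1190 nM so the two sit within the scatter of each other. Compound 3 (`CCCNC(=O)Nc1nc2ccc(-c3cnc(OC)c(NS(=O)(=O)c4ccc(F)cc4)c3)cn2n1`) brings the change methyl in place of piperidin-1-yl on a saturated chain carbon, two bonds along the chain from an amide-type nitrogen and reads as methyl in place of piperidin-1-yl on a saturated chain carbon, two bonds along the chain from an amide-type nitrogen. Among the compounds with values here, the only measured step bearing on this is a 2.0-fold lower number from compound 1 to compound 2 (0.29 log units; within the scatter) for (2-(piperidin-1-yl)ethyl)amino in place of dimethylamino on a carbonyl carbon, and it lies within the scatter. Compound 1 likewise has no piperidin-1-yl and stands at 1190 nM so no step beyond the scatter is expected in this assay for the new side chain. The estimated move is a 1.3-fold higher number from compound 2 to compound 3 (0.12 log units; within the scatter) and is expected to stay within the scatter. For compound 3 an estimate of 800 nM is expected, with 300 nM to 2000 nM as the estimated range.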

Compound 3, half-maximal inhibitory concentration: 220 nM
Estimate against measurement, compound 3: 3.6-fold (0.56 log units) above; the whole stated range lies above it.
By their numbers in this assay, from the lowest: compound 3; then compounds 2 and 1 (each within the scatter of the next).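

In this assay, methyl in place of piperidin-1-yl on a saturated chain carbon, two bonds along the chain from an amide-type nitrogen, gives a 2.8-fold lower number from compound 2 to compound 3 (0.44 log units; beyond the scatter) and so moves the number beyond the scatter, which the step of a 2.0-fold lower number from compound 1 to compound 2 (0.29 log units; within the scatter) did not do; the piperidin-1-yl ring is therefore not required for activity at this position. Propylamino in place of dimethylamino on a carbonyl carbon gives a 5.4-fold lower number from compound 1 to compound 3 (0.73 log units; beyond the scatter) and shows that this position can separate two small side chains beyond the scatter. Nothing available explains either step.

Going by these compounds, whether a longer chain such as butylamino would lower the number further remains open. Also open, on these data alone, is how an open-chain amine such as dimethylamino or a carboxylic acid at the end of the propyl chain would read.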